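A few compounds are considered here, and "the series" means these few. Any claim that something is new, unique, unknown or untested is made for them only; others in the source may bear on it.

Values in an ADME assay on microsomes (Homo sapiens) for metabolic stability (a lower number here means slower removal, a higher number faster removal of the compound), so far:
compound 1 (`CNC(=O)[C@@H]1CCCN1S(=O)(=O)c1ccc(Cl)c(COc2cccc3c(-n4ccnc4)cc(C)nc23)c1Cl`) gives 33.3 mL/min/kg
compound 2 (`CNC(=O)[C@@H]1CCCN1S(=O)(=O)c1cccc(COc2cccc3c(C(F)(F)F)cc(C)nc23)c1`) gives 50 mL/min/kg
compound 3 (`Cc1cc(C(F)(F)F)c2cccc(OCc3c(Cl)ccc(S(=O)(=O)N4CCC[C@H]4CO)c3Cl)c2n1`) gives 250 mL/min/kg

Compound 3 is the highest of the three, with compound 2 nearest and compound 1 furthest, and both gaps lie beyond the scatter. The next compound, compound 4 (`Cc1cc(C(F)(F)F)c2cccc(OCc3c(Cl)ccc(S(=O)(=O)N4CCC(C#N)CC4)c3Cl)c2n1`), has 4-cyanopiperidin-1-yl in place of 2-(hydroxymethyl)pyrrolidin-1-yl on a sulfonyl sulfur. For the measured compounds named here, no measured pair differs in one place only, so this change has no direct precedent. Going by the values given here, the sole guide is the spread of values: compound 3 at 250 mL/min/kg sits at the top, and compound 2 and compound 1 each differ from it in more than one place. From that top position, a fall is expected to be more likely than a rise, though its size is uncertain. The expected change is a 2.1-fold lower number from compound 3 to compound 4 (0.32 log units; beyond the scatter) and is estimated to lie near the edge of the scatter. Compound 4 is estimated at 120 mL/min/kg with an expected range from 45 mL/min/kg to 260 mL/min/kg as the upper end.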

Compound 4, clearance: 433 mL/min/kg
Beside the measured number, compound 4's estimate is 3.6-fold (0.56 log units) below it, outside the stated range (above it).
By their numbers in this assay, from the lowest: compounds 1 and 2 (each within the scatter of the next); then compounds 3 and 4 (each within the scatter of the next).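

For the compounds shown here, compound 3 and compound 4 form the first pair that differs in one place: on a sulfonyl sulfur, 4-cyanopiperidin-1-yl stands in place of 2-(hydroxymethyl)pyrrolidin-1-yl. In this assay this change gives a 1.7-fold higher number from compound 3 to compound 4 (0.24 log units; within the scatter), so on this core the read-out does not separate the two groups. The exchange replaces a five-membered ring with a six-membered ring and removes both the hydrogen-bond donor and the defined stereocentre, yet no difference beyond the scatter appears, and no supporting data bear on the reason for this.

Ring size and the substituent changed together here, so the contribution of each remains unresolved. Also open, from the compounds shown here alone, is whether a different group on the sulfonyl sulfur, such as morpholine or a piperidine carrying a carboxylic acid, would separate from this pair.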